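The source may hold more compounds than are shown below. What is called first, only, known or untested is meant among the compounds shown, and "the series" means these compounds.

Measured compounds:
- compound 1, `COc1cc(C)cc(-c2c(-c3ccnc(-c4ccc(C(C)=O)cc4)c3)cnn2CC#N)c1`: 1930 nM
- compound 2, `Cc1cc(O)cc(-c2nn(CC#N)cc2-c2ccnc(-c3ccc(Oc4ccccc4)cc3)c2)c1`: 2720 nM
- compound 3, `COc1cc(C)cc(-c2nn(CC#N)cc2-c2ccnc(-c3ccc(N(C)C)cc3)c2)c1`: 196 nM

In a functional assay on NCI-H522 cells (Homo sapiens) for inhibition, read by sulforhodamine B assay, with a stated time of 48 h (on this read-out higher numbers stand for weaker inhibition of growth and lower numbers for stronger inhibition of growth), compound 3 stands lowest of the three numbers. Compound 1 gives a number that is beyond the scatter above it, and compound 2 gives a number that is further above it still, also beyond the scatter. The three compounds share a core and differ in several places at once, so no single change among them can be read on its own.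

Compound 4, `Cc1cc(O)cc(-c2nn(CC#N)cc2-c2ccnc(-c3ccc(N(C)C)cc3)c2)c1`, differs from compound 3 in one place: hydrogen in place of methyl on an oxygen on an aromatic ring. Going by the values given here, no pair of measured compounds shows this change by itself. Compound 2 carries the hydroxy group, compound 1 the methoxy group, but they also differ elsewhere, so their values say nothing direct about this step. Without a comparable step, a small change in either direction is expected, at most a modest weakening, since the step from compound 3 to compound 4 is estimated as a 1.6-fold higher number from compound 3 to compound 4 (0.21 log units; within the scatter). Compound 4 is therefore expected to give about 320 nM in this assay, within a range of 100 nM to 1200 nM.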

Compound 4, concentration for 50% growth inhibition: 1930 nM
Compound 4: the middle estimate sits 6.0-fold (0.78 log units) below what was measured; measured number above the stated range.
By their numbers in this assay, from the lowest: compound 3; then compounds 1, 4 and 2 (each within the scatter of the next).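

In this assay, the change from 3-methoxy-5-methylphenyl to 3-hydroxy-5-methylphenyl can now be read on its own, and it gives a 9.8-fold higher number from compound 3 to compound 4 (0.99 log units; beyond the scatter) with the dimethylamino group held fixed, so the methyl on this oxygen counts for much of the low number of compound 3. With the hydroxy group held fixed, dimethylamino in place of phenoxy gives a 1.4-fold lower number from compound 2 to compound 4 (0.15 log units; within the scatter) and so shows no change, which means dimethylamino alone does not bring the low number. No measurement shown here explains either result.

From the compounds shown here alone, whether ethoxy or an amine at this place would keep the number of compound 3 remains open. So does whether the step from methoxy to hydroxy has the same size when phenoxy replaces dimethylamino.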